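The compounds below may be only part of what the source reports. "The series", "measured", "known", "first", "only" and "open" are said of these compounds alone.

Measured in a toxicity assay on A-375 cells (Homo sapiens) for cytotoxicity, read by CCK-8 assay, with stated times of 16 h and 24 h; a lower number here means a stronger inhibitor, a higher number a weaker inhibitor:
- compound 1 `COc1ccc(C2=[N+]3C(=Nc4c(-c5ccccc5)c5c(n4[B-]3(F)F)-c3ccc(OCC(=O)N[C@@H](CC(=O)O)C(=O)O)cc3CC5)C(c3ccccc3)=C2I)cc1`: 81 nM
- compound 2 `COc1ccc(C2=[N+]3C(=Nc4c(-c5ccccc5)c5c(n4[B-]3(F)F)-c3ccc(OCC(=O)N[C@@H](CCC(=O)O)C(=O)O)cc3CC5)C(c3ccccc3)=C2I)cc1`: 166 nM
- compound 3 `COc1ccc2c(c1)CCc1c(-c3ccccc3)c3n(c1-2)[B-](F)(F)[N+]1=C(c2ccc(OCC(=O)O)cc2)C(I)=C(c2ccccc2)C1=N3`: 320 nM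

Compound 3 at 320 nM lies within the scatter of compound 2, while compound 1 reads a lower number, beyond the scatter.

Compound 4 `COc1ccc2c(c1)CCc1c(-c3ccccc3)c3n(c1-2)[B-](F)(F)[N+]1=C(c2ccc(OCC(=O)N[C@@H](CCC(=O)O)C(=O)O)cc2)C(I)=C(c2ccccc2)C1=N3` has (1,3-dicarboxypropyl)amino in place of hydroxy on a carbonyl carbon of compound 3: (1,3-dicarboxypropyl)amino in place of hydroxy on a carbonyl carbon.

Among the measured compounds shown here, the only measured step, a 2.0-fold higher number from compound 1 to compound 2 (0.31 log units; beyond the scatter), is modest and concerns carboxymethyl in place of carboxy on a saturated chain carbon. For the measured compounds named here, it bears on the side chain only, and no measured step covers the change from acid to amide. The nearest guide is compound 2 at 166 nM, which carries the same (1,3-dicarboxypropyl)carbamoyl group elsewhere on the shared core. A small move to a lower number, within the scatter, is therefore expected in this assay. The expected step is a 1.5-fold lower number from compound 3 to compound 4 (0.18 log units; within the scatter). Compound 4 is estimated at 210 nM, with an expected range of 90 nM to 480 nM.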

Compound 4, half-maximal inhibitory concentration in the A-375 assay: 284 nM
Beside the measured number, compound 4's estimate is 1.4-fold (0.13 log units) below it; low and high end bracket the measured number.
By their numbers in the A-375 assay, from the lowest: compound 1; then compounds 2, 4 and 3 (each within the scatter of the next).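

In the A-375 assay, placing (1,3-dicarboxypropyl)amino in place of hydroxy on this carbonyl carbon, whose other neighbour is a saturated chain carbon, stays within the scatter (a 1.1-fold lower number from compound 3 to compound 4 (0.05 log units; within the scatter)). Among the compounds shown here, the earlier compounds offered no pair for this change from acid to amide, so this is the first reading of it at this position. In a physicochemical assay for solubility, in phosphate buffer (on this read-out higher numbers stand for higher solubility and lower numbers for lower solubility), compound 3 gives 21800 nM and compound 4 gives 110000 nM. In the physicochemical assay, the same change separates the two compounds beyond the scatter, so this pair shows solubility shifting while the cytotoxicity reading holds: (the measured solubility of compound 3, 21800 nM, and of compound 4, 110000 nM, a 5.0-fold higher number (0.70 log units; beyond the scatter)).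

Still open, from the compounds shown here alone, is whether the shorter diacid chain of compound 1 would read differently at this position. Also open, going by these compounds, is whether a chain ending in a sulfonic acid, or a plain amine in place of the hydroxy, would give a comparable pair of readings.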